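This account rests on a few compounds, and the source may have more. Where it says the series, first, only, none or still open, it means among the compounds named here.

In an assay on isolated protein for inhibition of Amine oxidase [flavin-containing] B (Homo sapiens) (on this read-out lower numbers stand for stronger inhibition and higher numbers for weaker inhibition), compound 2 `C#CCNC1CCc2c(SCCc3cccc(F)c3)cccc21` gives 4300 nM. Among the measured compounds shown here, only one other number exists for comparison: compound 1 `C#CCNC1CCc2c(SCCc3cccc(C(F)(F)F)c3)cccc21` gives 3720 nM in this assay, and the step of a 1.2-fold higher number from compound 1 to compound 2 (0.06 log units; within the scatter) lies within the scatter, so the two compounds cannot be told apart on this read-out. Compound 3 `C#CCNC1CCc2c(SCCc3cccc(Cl)c3)cccc21` has not yet been measured in this assay. It differs from compound 2 in one place: chloro in place of fluoro on an aromatic carbon, on the same aromatic carbon that carries trifluoromethyl in compound 1 and fluoro in compound 2. For the measured compounds named here, the one measured step that bears on this position is a 1.2-fold higher number from compound 1 to compound 2 (0.06 log units; within the scatter), which stayed within the scatter, so no step beyond the scatter is expected in this assay from this second exchange at that carbon. Compound 3 is therefore expected to give 3500 nM in this assay, within a range from 1500 nM to 8000 nM. The expected step of a 1.2-fold lower number from compound 2 to compound 3 (0.09 log units; within the scatter) is estimated to be small.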

Compound 3, half-maximal inhibitory concentration: 82400 nM
The estimate for compound 3 lay 24-fold (1.37 log units) below the measured number, and the stated range ends below it.
By their numbers in this assay, from the lowest: compounds 1 and 2 (each within the scatter of the next); then compound 3.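

In this assay, this aromatic carbon turns out not to be indifferent to what it carries: the change from 3-fluorophenyl to 3-chlorophenyl gives a 19-fold higher number from compound 2 to compound 3 (1.28 log units; beyond the scatter), and chloro in place of trifluoromethyl gives a 22-fold higher number from compound 1 to compound 3 (1.35 log units; beyond the scatter). The earlier pair showed no step beyond the scatter at this carbon, whereas chloro now sets compound 3 apart from both compound 1 and compound 2, whose fluoro and trifluoromethyl groups cannot be told apart on this read-out. Nothing in the information available accounts for this result.

On these data alone, it remains open whether the large step belongs to chloro alone or would also appear with bromo, methyl or methoxy on this carbon. Also open, as far as these compounds go, is whether it would persist with an oxygen in place of the sulfur in the chain.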